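Restoring the hydroxy group on the shared core

The source may report more compounds than this note shows. Statements on the series, on what has been measured and on what is new or still open speak of the compounds shown alone.

Compound 1 `Cc1c(OCCCCOc2ccc(C(=O)O)cc2)ccc(C(=O)CC2CCCC2)c1O`: 82.6%
Compound 2 `Cc1c(OCCCCOc2ccc(C(=O)O)cc2F)ccc(C(=O)CC(C)C)c1O`: 85%
Compound 3 `Cc1c(OCCCCOc2ccc(C(=O)O)cc2)ccc(C(=O)CC(C)C)c1C`: 19%

In an assay on HEK293 cells for positive allosteric modulation of metabotropic glutamate receptor 2 (Rattus norvegicus), read by thallium flux, with a stated time of 2.5 min (on this read-out higher numbers stand for larger maximal responses and lower numbers for smaller maximal responses), compound 3 gives the lowest of the three values; the nearest value, that of compound 1, lies well beyond the scatter, and that of compound 2 lies further still. Compound 4 `Cc1c(OCCCCOc2ccc(C(=O)O)cc2)ccc(C(=O)CC(C)C)c1O` differs from compound 3 in one place: hydroxy in place of methyl on an aromatic carbon. This returns the hydroxy group that compound 1 and compound 2 carry on their core. Since compound 1 gives 82.6% and compound 2 gives 85% in this assay, the expected step is a number 61 percentage points higher from compound 3 to compound 4 (beyond the scatter), an upward move clearly beyond the scatter. Compound 4 is expected to give 80%, with a range from 60% to 95%.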

Compound 4, largest response reached (reported as percent of maximum), in percent of the reference or control that the assay uses: 88%
Beside the measured number, compound 4's estimate is 8 percentage points below it; low and high end bracket the measured number.
By their numbers in this assay, from the lowest: compound 3; then compounds 1, 2 and 4 (each within the scatter of the next).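

Hydroxy in place of methyl on this aromatic carbon gives a number 69 percentage points higher from compound 3 to compound 4 (beyond the scatter) in this assay and is the only one of the three new comparisons that lies beyond the scatter. With the hydroxy group in place, the maximal response holds through two other changes: hydrogen in place of fluoro gives a number 3 percentage points higher from compound 2 to compound 4 (within the scatter) and isopropyl in place of cyclopentyl gives a number 5.4 percentage points higher from compound 1 to compound 4 (within the scatter) as well. Nothing measured here says why the hydroxy group matters so much.

On these data alone, how a methoxy group or an amine would fare on this aromatic carbon stays open. So does the effect of a longer chain in place of the isobutylcarbonyl group.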